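Changing the Aryl Group on the Ring Nitrogen

A few compounds are considered here, and "the series" means these few. Any claim that something is new, unique, unknown or untested is made for them only; others in the source may bear on it.

compound 1 `COc1ccc(-n2nc(-c3ccc(C(F)(F)F)cc3O)nc2-c2ccccc2O)cc1`: 69%
compound 2 `Oc1cc(C(F)(F)F)ccc1-c1nc(-c2ccccc2O)n(-c2ccccc2F)n1`: 63.4%
compound 3 `Oc1cc(C(F)(F)F)ccc1-c1nc(-c2ccccc2O)n(-c2cccc(C(F)(F)F)c2)n1`: 71.5%

Three compounds share one core and differ only in the aryl group on an aromatic nitrogen. In a functional assay on PC-12 cells (Rattus norvegicus) for cytotoxicity, read by MTT assay, with stated times of 2 h and 24 h, tested at 1 uM (a lower number here means a weaker effect, a higher number a stronger effect of the compound at the concentration tested), compound 1 gives 69%, compound 2 gives 63.4% and compound 3 gives 71.5%. Compound 2 has the lowest of the three numbers, yet both gaps stay within the scatter: a number 5.6 percentage points lower from compound 1 to compound 2 (within the scatter) and a number 8.1 percentage points higher from compound 2 to compound 3 (within the scatter); likewise a number 2.5 percentage points higher from compound 1 to compound 3 (within the scatter). Compound 4 `Cc1cc(C)cc(-n2nc(-c3ccc(C(F)(F)F)cc3O)nc2-c2ccccc2O)c1` is not yet measured and differs from compound 2 by 3,5-dimethylphenyl in place of 2-fluorophenyl on an aromatic nitrogen. All three measured steps swap one aryl group at this same place without moving the number beyond the scatter, so no step beyond the scatter is expected here either. For compound 4 the estimate is 67%, within 57% to 77%. That estimate means a number 3.6 percentage points higher from compound 2 to compound 4 (within the scatter) is expected.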

Compound 4, a percentage reported as activity, at one concentration (the size of the read-out at that concentration, not a potency): 76.9%
The estimate for compound 4 lay 9.9 percentage points below the measured number; low and high end bracket the measured number.
By their numbers in this assay, from the lowest: compounds 2, 1, 3 and 4 (each within the scatter of the next, the first and the last beyond it).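

In this assay, an aryl swap on the aromatic nitrogen now produces a step beyond the scatter, with a number 13.5 percentage points higher from compound 2 to compound 4 (beyond the scatter) as the only such step among the compounds shown. The other two steps to the 3,5-dimethylphenyl group stay within the scatter, with a number 5.4 percentage points higher from compound 3 to compound 4 (within the scatter) and a number 7.9 percentage points higher from compound 1 to compound 4 (within the scatter), so this single pair alone separates at this position. No measurement at hand accounts for that step. Every group shown at this nitrogen is an aryl group, so the effect of an amine or a carboxylic acid on a longer chain there remains open.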